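The source may hold more compounds than are shown below. What is called first, only, known or untested is meant among the compounds shown, and "the series" means these compounds.

Measured so far in a functional assay on A375P cells (Homo sapiens) for antiproliferative activity; on this read-out higher numbers stand for weaker inhibition and lower numbers for stronger inhibition:
Compound 1, `CC(=O)Nc1cc(NC(=O)Nc2ccc(Cl)c(Cl)c2)ccc1C`: 2100 nM
Compound 2, `CC(=O)Nc1cc(NC(=O)Nc2cc(F)cc(C(F)(F)F)c2)ccc1C`: > 30000 nM

Compound 1 gives a number in this assay, 2100 nM. For compound 2 this assay reports only a limit, > 30000 nM, and no number; it sits at the limit of > 30000 nM in this assay, at which 1 of the 2 values shown sits. Compound 3, `Cc1ccc(NC(=O)Nc2cc(F)cc(C(F)(F)F)c2)cc1NC(=O)c1ccccc1`, is not yet measured. It differs from compound 2 in one place: phenyl in place of methyl on a carbonyl carbon. Among the compounds with values here, no measured pair carries this change, so its size is unknown; compound 3 is expected to come in somewhat stronger than the limit of compound 2, a step of an at least 3.0-fold lower number from compound 2 to compound 3 (0.47 log units; beyond the scatter) being expected. For compound 3 the estimated value in this assay is 10000 nM, within 2000 nM to 30000 nM.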

Compound 3, half-maximal inhibitory concentration: > 30000 nM
Compound 3 ended at the assay's limit (the forecaster's own chance of this, stated with the estimate: 40%); middle value at least 3.0-fold (0.47 log units) away from the limit.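

No step can be read from compound 2 to compound 3, because both give only a limit and no number: the limit of > 30000 nM in this assay, at which 2 of the 3 values shown sit.

The compounds shown leave open what phenyl in place of methyl on a carbonyl carbon does to the activity when a compound gives a measurable number.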